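Swapping hydroxy for chloro on the outer amide ring

The source may hold more compounds than are shown below. What is called first, only, known or untested is meant among the compounds shown, and "the series" means these compounds.

Compound 1 `CN(C)C(=O)c1cc2cnc(Nc3ccc(NC(=O)C4(C(=O)Nc5ccccc5)CC4)cc3)nc2n1C1CCCC1` gives 42.4% in a functional assay on NCI-H460 cells (Homo sapiens) for inhibition, read by CCK-8 assay, with a stated time of 72 h, tested at 1 uM; on this read-out lower numbers stand for less inhibition of growth and higher numbers for more inhibition of growth at the one concentration tested.
Compound 2 `CN(C)C(=O)c1cc2cnc(Nc3ccc(NC(=O)C4(C(=O)Nc5ccc(Cl)c(C(F)(F)F)c5)CC4)cc3)nc2n1C1CCCC1` gives 2.1% in this assay.
Compound 3 `CN(C)C(=O)c1cc2cnc(Nc3ccc(NC(=O)C4(C(=O)Nc5ccc(O)cc5)CC4)cc3)nc2n1C1CCCC1` gives 90.4% in this assay.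

Compound 3 stands highest of the three in this assay, separated from the others by a number 48 percentage points higher from compound 1 to compound 3 (beyond the scatter) and by a number 88.3 percentage points higher from compound 2 to compound 3 (beyond the scatter), both beyond the scatter. Compound 4 `CN(C)C(=O)c1cc2cnc(Nc3ccc(NC(=O)C4(C(=O)Nc5ccc(Cl)cc5)CC4)cc3)nc2n1C1CCCC1` differs from compound 3 by chloro in place of hydroxy on an aromatic carbon. Among the compounds with values here, two measured steps bear on this change. The step of a number 48 percentage points higher from compound 1 to compound 3 (beyond the scatter) shows how much the hydroxy group added, and removing it should give most of that back. The step of a number 40.3 percentage points lower from compound 1 to compound 2 (beyond the scatter), where a chloro arrives together with a trifluoromethyl, points downward as well. A large fall in this assay is therefore expected, namely a number 65.4 percentage points lower from compound 3 to compound 4 (beyond the scatter). Compound 4 is estimated at 25%, with a range from 5% to 50%.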

Compound 4, percent growth inhibition at one concentration: 21.3%
Compound 4: middle estimate off by 3.7 percentage points, on the high side; the measured number falls inside the stated range.
By their numbers in this assay, from the lowest: compound 2; then compound 4; then compound 1; then compound 3.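

At this place on the outer ring, the two groups push the number in opposite directions in this assay: chloro alone lowers it (a number 21.1 percentage points lower from compound 1 to compound 4 (beyond the scatter)), so the swap from hydroxy (a number 69.1 percentage points lower from compound 3 to compound 4 (beyond the scatter)) loses more than the hydroxy gain alone. The earlier combined change can now be split, since removing trifluoromethyl from the chloro ring still leaves a measurable rise (a number 19.2 percentage points higher from compound 2 to compound 4 (beyond the scatter)). Nothing available here explains why these groups differ.

Open, on these data alone, is how an amino or methoxy group at this same place would compare with hydroxy and chloro. Also open, as far as these compounds go, is whether hydroxy keeps its gain with a trifluoromethyl on the same ring.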